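Aryl swap on the shared core: alpha-2B agonist efficacy

The compounds below may be only part of what the source reports. "The series", "measured", "known", "first", "only" and "open" are said of these compounds alone.

compound 1 `CC(Oc1ccccc1-c1cccnc1)C1=NCCN1` — 0.5
compound 2 `Cc1cccc(-c2ccccc2OC(C)C2=NCCN2)c1` — < 0.3

Compound 2 `Cc1cccc(-c2ccccc2OC(C)C2=NCCN2)c1` gives < 0.3 in a functional assay on CHO cells for agonist activity at Alpha-2B adrenergic receptor (Homo sapiens) (a lower number here means a smaller maximal response, a higher number a larger maximal response), which is a limit of the assay rather than a number; it sits at the limit of < 0.3 in this assay, at which 1 of the 2 values shown sits. Compound 1 `CC(Oc1ccccc1-c1cccnc1)C1=NCCN1` gives 0.5 in this assay. Among the measured compounds shown here, the only measured step is a number at least 0.20 lower from compound 1 to compound 2 (beyond the scatter), where a six-membered heteroaryl gave the larger response. Compound 3 `CC(Oc1ccccc1-c1cccs1)C1=NCCN1` carries the change (thiophen-2-yl in place of 3-methylphenyl on an aromatic carbon), a small heteroaryl again. Compound 3 is therefore expected to recover part of that response, estimated at 0.4 with a range of 0.25 to 0.6. The expected step is a number at least 0.10 higher from compound 2 to compound 3 (that floor lies within the scatter).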

Compound 3, intrinsic activity: the largest response reached, as a fraction of the reference agonist's: 0.6
For compound 3 the middle estimate is 0.20 below the measured one; the measured number falls inside the stated range.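

A five-membered aromatic ring at this aromatic carbon restores the response, so a six-membered heteroaryl is not required: thiophen-2-yl in place of 3-methylphenyl in this assay gives a number at least 0.30 higher from compound 2 to compound 3 (beyond the scatter). Thiophen-2-yl and pyridin-3-yl are not separated, with a number 0.10 higher from compound 1 to compound 3 (within the scatter). Compound 2 remains a limit of the assay, not a number: the limit of < 0.3 in this assay, at which 1 of the 3 values shown sits.

Still open, from the compounds shown here alone, is whether the loss with 3-methylphenyl follows from the methyl or from the all-carbon ring, which unsubstituted phenyl would separate. Also open, going by these compounds, is how an amine on the thiophene ring would shift the maximal response.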